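The source may hold more compounds than are shown below. What is called first, only, known or untested is meant among the compounds shown, and "the series" means these compounds.

Compound 1 `COc1ccc(-n2c(SCC(=O)C3CC3)nnc2-c2cc(OC)c(OC)c(OC)c2)cc1` gives > 60000 nM as a limit
Compound 2 `COc1ccc(C(=O)CSc2nnc(-c3cc(OC)c(OC)c(OC)c3)n2-c2ccc(N(C)C)cc2)cc1O` gives > 100000 nM as a limit

In a functional assay on HepG2 cells (Homo sapiens) for inhibition, read by MTT assay, with a stated time of 48 h (on this read-out lower numbers stand for stronger inhibition and higher numbers for weaker inhibition), compound 2 stands at > 100000 nM and this is a limit of the assay, not a number. Compound 3 `COc1cc(-c2nnc(SCC(=O)C3CC3)n2-c2ccc(N(C)C)cc2)cc(OC)c1OC` has not yet been measured. It has cyclopropyl in place of 3-hydroxy-4-methoxyphenyl on a carbonyl carbon. Compound 1 also carries cyclopropyl on its carbonyl carbon, and it reads > 60000 nM as a limit too. On that basis no clear gain in inhibition is expected for compound 3 in this assay and another limit may well be reported. The estimated step of an at least 1.2-fold lower number from compound 2 to compound 3 (0.09 log units; that floor lies within the scatter) is expected to stay within the usual scatter. The estimate for compound 3 is 80000 nM with an expected range from 25000 nM to 200000 nM in this assay on this read-out.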

Compound 3, half-maximal inhibitory concentration: > 60000 nM
Compound 3: a limit, no number (the forecaster's own chance of this, stated with the estimate: 60%); the middle value is on the limit's open side.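

In this assay, compound 3 also gives only a limit, so neither the step from compound 2 to compound 3 nor the step from compound 1 to compound 3 can be read. The compounds shown leave open how cyclopropyl compares with 3-hydroxy-4-methoxyphenyl on a carbonyl carbon, and dimethylamino with methoxy on an aromatic carbon.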